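Removing an acetyl group on a coumarin-linked furoxan series

The source may hold more compounds than are shown below. What is called first, only, known or untested is meant among the compounds shown, and "the series" means these compounds.

Of the compounds shown here, three have been measured in a functional assay on MCF7 cells (Homo sapiens) for inhibition, read by MTT assay, with a stated time of 48 h; a lower number here means a stronger inhibitor, a higher number a weaker inhibitor. Compound 1 `COc1cc2cc(NC(C)=O)c(=O)oc2cc1OCCOc1no[n+]([O-])c1S(=O)(=O)c1ccccc1` gives 6890 nM. Compound 2 `COc1cc2cc(NC(C)=O)c(=O)oc2cc1OCCCCOc1no[n+]([O-])c1S(=O)(=O)c1ccccc1` carries a longer chain linking the two ring systems of the molecule; the difference between the two cores is not broken down here. In this assay compound 2 gives 3440 nM, which sits within the usual scatter of the value for compound 1. Compound 3 `COc1cc2cc(N)c(=O)oc2cc1OCCOc1no[n+]([O-])c1S(=O)(=O)c1ccccc1` gives 2770 nM in this assay, and this value lies within the scatter of the value for compound 2, so no order can be drawn between compounds 2 and 3.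

For the measured compounds named here, the one change that has been measured directly is the step from compound 1 to compound 3: hydrogen in place of acetyl on a nitrogen on an aromatic ring This step produced a 2.5-fold lower number from compound 1 to compound 3 (0.40 log units; beyond the scatter) in this assay, a shift that goes beyond the scatter.

Compound 4 `COc1cc2cc(N)c(=O)oc2cc1OCCCCOc1no[n+]([O-])c1S(=O)(=O)c1ccccc1` has not yet been measured. It stands to compound 2 exactly as compound 3 stands to compound 1: hydrogen in place of acetyl on a nitrogen on an aromatic ring The place of the change is the same in both pairs, so this is the same change made on the core of compound 2. Because the step of a 2.5-fold lower number from compound 1 to compound 3 (0.40 log units; beyond the scatter) was modest but real, a step of similar size is expected here, giving a 2.5-fold lower number from compound 2 to compound 4 (0.39 log units; beyond the scatter) in this assay. Going by the values given here, compound 4 is therefore estimated to give 1400 nM in this assay, with a likely range from 600 nM to 3200 nM, which rests on the single measured example of this change and on the value of compound 2 3440 nM.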

Compound 4, half-maximal inhibitory concentration: 2280 nM
Compound 4: the middle estimate sits 1.6-fold (0.21 log units) below what was measured; the measured number falls inside the stated range.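

On the core of compound 2, the acetamido to amino change gives a 1.5-fold lower number from compound 2 to compound 4 (0.18 log units; within the scatter) in this assay, so on this core the step cannot be told apart from the ordinary noise of repeated measurements. Set beside the earlier step on the core of compound 1, the new step gives no sign that the core alters the effect of this change, since the gap between the two steps is no larger than such measurements can blur: the same change on two cores in this assay, a 2.5-fold lower number (0.40 log units; beyond the scatter) from compound 1 to compound 3 and a 1.5-fold lower number (0.18 log units; within the scatter) from compound 2 to compound 4, 1.6-fold (0.22 log units) apart, within the scatter of two such steps This does not show that the change reliably gives a lower number on both cores, as only the step on the core of compound 1 clears the scatter, and two pairs are too few to fix the size of the step or to rule out a modest difference between the cores.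

The compounds shown leave open what other groups on that nitrogen would do, such as a methyl group or a propionyl group, and whether the same comparison would hold with a longer chain joining the two ring systems. They also leave open whether the step would look the same on other cell lines.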